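Cyano in place of fluoro on the aromatic ring

A few compounds are considered here, and "the series" means these few. Any claim that something is new, unique, unknown or untested is made for them only; others in the source may bear on it.

Compound 1 (`CCC(=O)N(c1ccc(F)cc1)C1CCCC1N(C)C`) is the starting point for this step. In a functional assay on the whole organism for positive allosteric modulation, with Mus musculus as the target (a lower number here means that less compound is needed, a higher number that more compound is needed for the effect), compound 1 gives > 50 mg/kg, which is a limit of the assay and not a number. Its position therefore rests only on (the limit of > 50 mg/kg in this assay, at which 1 of the 2 values shown sits). Compound 2 (`CCC(=O)N(c1ccc(F)c(Cl)c1)C1CCCC1N(C)C`) gives 0.7 mg/kg in this assay.

Compound 3 (`CCC(=O)N(c1ccc(C#N)cc1)C1CCCC1N(C)C`) differs from compound 1 by cyano in place of fluoro on an aromatic carbon, para to a large group. Among the measured compounds shown here, no measured step makes this exchange. The nearest evidence is the large step of an at least 71-fold lower number from compound 1 to compound 2 (1.85 log units; beyond the scatter), beyond the scatter, which is chloro in place of hydrogen on an aromatic carbon with fluoro retained. That step shows that one substitution on this ring can shift the number strongly, but it transfers only loosely to a different group at a different place. A moderate move towards a lower number is therefore expected, with low confidence: an at least 5.0-fold lower number from compound 1 to compound 3 (0.69 log units; beyond the scatter). For compound 3 the estimated value is 10 mg/kg, with an expected range of 2 mg/kg to 50 mg/kg. A result reported only as a limit also remains possible.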

Compound 3, dose for half-maximal effect: > 50 mg/kg
Compound 3: no number, only a limit (the forecaster's own chance of this, stated with the estimate: 35%); middle value at least 5.0-fold (0.69 log units) away from the limit.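

Compound 1 and compound 3 are both reported only as limits in this assay, so no step can be read for cyano in place of fluoro: the limit of > 50 mg/kg in this assay, at which 2 of the 3 values shown sit.

The compounds shown leave open whether this exchange shifts the number in either direction, and whether cyano combined with chloro would give a measurable number, as fluoro combined with chloro does in compound 2.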